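This account rests on a few compounds, and the source may have more. Where it says the series, first, only, none or still open, it means among the compounds named here.

In a functional assay on MCF7 cells (Homo sapiens) for cytotoxicity, read by MTT assay, with a stated time of 48 h (a higher number here means a weaker inhibitor, a lower number a stronger inhibitor), compound 3 `CCCCCCCCCCCCCCCCCCNC(=O)[C@@H](NC(=O)c1cc2ccccc2[nH]1)[C@@H](C)O` gives 35700 nM, the highest of the three numbers, though its gaps to compound 2 `CCCCCCCCCCCCCCCCCCNC(=O)[C@@H](NC(=O)c1ccccc1)[C@@H](C)O` at 31800 nM and to compound 1 `CCCCCCCCCCCCNC(=O)[C@@H](NS(=O)(=O)c1cccs1)[C@@H](C)O` at 19100 nM both lie within the scatter. For the measured compounds named here, the only measured step, a 1.1-fold higher number from compound 2 to compound 3 (0.05 log units; within the scatter), likewise stays within the scatter. Compound 4 `CCCCCCCCCCCCCCCCCCNC(=O)[C@@H](NS(=O)(=O)c1cccs1)[C@@H](C)O` differs from compound 3 by (thiophen-2-yl)sulfonyl in place of (1H-indol-2-yl)carbonyl on an amine nitrogen. Going by the values given here, no measured step covers this change; compound 1 also bears the (thiophen-2-yl)sulfonyl group, and its value sits within the scatter of compound 3, so the three values together are the only guide. Compound 4 is therefore expected to show a 1.4-fold lower number from compound 3 to compound 4 (0.15 log units; within the scatter), a step no larger than the scatter. The estimate for compound 4 is 25000 nM, within 10000 nM to 60000 nM.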

Compound 4, half-maximal inhibitory concentration: > 200000 nM
Compound 4 ended at the assay's limit; the forecaster's own chance of this, stated with the estimate: 5%; middle value at least 8.0-fold (0.90 log units) away from the limit.
By their numbers in this assay, from the lowest: compounds 1, 2 and 3 (each within the scatter of the next). At a limit, above all of these: compound 4.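

Compound 4 stands at a limit of this assay, not at a number: the limit of > 200000 nM in this assay, at which 1 of the 4 values shown sits.

On the amine nitrogen, this position now responds to the group it carries: (thiophen-2-yl)sulfonyl gives an at least 5.6-fold higher number from compound 3 to compound 4 (0.74 log units; beyond the scatter) and an at least 6.2-fold higher number from compound 2 to compound 4 (0.79 log units; beyond the scatter), whereas a 1.1-fold higher number from compound 2 to compound 3 (0.05 log units; within the scatter) had stayed within the scatter. With the (thiophen-2-yl)sulfonyl group held, the chain also counts, as hexyl in place of hydrogen gives an at least 10-fold higher number from compound 1 to compound 4 (1.01 log units; beyond the scatter).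

The compounds shown leave open whether the sulfonyl link or the thiophene ring carries the change, a question that a (thiophen-2-yl)carbonyl or a phenylsulfonyl group on the same nitrogen would address.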